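From benzyloxy to methoxy on a single measured value

The source may report more compounds than this note shows. Statements on the series, on what has been measured and on what is new or still open speak of the compounds shown alone.

Among the measured compounds shown here, in an ADME assay on J774.A1 cells (Mus musculus) for cytotoxicity, read by MTT assay, with a stated time of 72 h (on this read-out higher numbers stand for lower toxicity in this test and lower numbers for higher toxicity in this test), compound 1 `COC(=O)C1=C(C)N(c2ccc(Cl)cc2)C(C)=C(C(=O)OC)C1[C@@H]1O[C@H]2OC(C)(C)O[C@H]2[C@@H]1OCc1ccccc1` gives 4.22 ug/mL as the only number available. Compound 2 `COC(=O)C1=C(C)N(c2ccc(F)cc2)C(C)=C(C(=O)OC)C1[C@@H]1O[C@H]2OC(C)(C)O[C@H]2[C@@H]1OCc1ccccc1` stands at "not determined" (no result reported) in this assay and offers no comparison, so compound 1 cannot be ranked against anything. Compound 3 `COC(=O)C1=C(C)N(c2ccc(Cl)cc2)C(C)=C(C(=O)OC)C1[C@@H]1O[C@H]2OC(C)(C)O[C@H]2[C@@H]1OC` keeps the core of compound 1 and changes in one place, with hydrogen in place of phenyl on a saturated chain carbon bound to an oxygen on a saturated carbon giving hydrogen in place of phenyl on a saturated chain carbon bound to an oxygen on a saturated carbon, so that benzyloxy becomes methoxy. For the measured compounds named here, no measured pair shows what this change does, so the expectation rests on compound 1 with its 4.22 ug/mL alone. In this assay the estimated step is a 1.9-fold higher number from compound 1 to compound 3 (0.28 log units; within the scatter) and points modestly toward lower toxicity, though a result within the scatter remains possible. Compound 3 is expected at 8 ug/mL with an estimated range of 3 ug/mL to 25 ug/mL as the two ends of that expectation.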

Compound 3, half-maximal cytotoxic concentration: 82.4 ug/mL
Compound 3: the middle estimate sits 10-fold (1.01 log units) below what was measured, outside the stated range (above it).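

In this assay, replacing benzyloxy with methoxy is a large change rather than a minor adjustment: the step is a 20-fold higher number from compound 1 to compound 3 (1.29 log units; beyond the scatter) and points toward lower toxicity in this test. This gives compound 1 its first measured partner and shows that the group on a saturated chain carbon bound to an oxygen on a saturated carbon strongly affects this read-out, at least for this pair. No measurement at hand explains why losing the phenyl has so large an effect.

This single pair cannot show how an ethyl group, a longer chain or a benzyl carrying a methoxy group would behave at this place. Nor can it show whether the same step would appear with the change made on a different core.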